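From Methylamino to Fluorobenzylamino in an Adenosine Receptor Series

The source may report more compounds than this note shows. Statements on the series, on what has been measured and on what is new or still open speak of the compounds shown alone.

Compound 1 `CCCCC#Cc1nc(NCc2cccc(I)c2)c2ncn([C@H]3[C@H](O)[C@H](O)[C@@H]4C[C@@H]43)c2n1`: 26 nM
Compound 2 `CCCCC#Cc1nc(NC)c2ncn([C@H]3[C@H](O)[C@H](O)[C@@H]4C[C@@H]43)c2n1`: 231 nM

In an assay on RBL-2H3 cells for displacement of a labelled ligand from adenosine receptor A3 (Rattus norvegicus), with a stated time of 60 min (a lower number here means a stronger inhibitor, a higher number a weaker inhibitor), compound 1 gives 26 nM and compound 2 gives 231 nM, the higher of the two numbers. Compound 3 `CCCCC#Cc1nc(NCc2cccc(F)c2)c2ncn([C@H]3[C@H](O)[C@H](O)[C@@H]4C[C@@H]43)c2n1` differs from compound 2 by 3-fluorophenyl in place of hydrogen on a saturated chain carbon bound to a nitrogen on an aromatic ring. Among the measured compounds shown here, the one step that bears on this change is an 8.9-fold higher number from compound 1 to compound 2 (0.95 log units; beyond the scatter), showing that stripping the iodinated benzyl down to hydrogen weakened binding. Putting a benzyl group back, now carrying fluorine, is therefore expected to lower the number again, though the gain need not fully match the one seen with iodine. Compound 3 is expected to give 50 nM (range 18 nM to 140 nM), a step of a 4.6-fold lower number from compound 2 to compound 3 (0.66 log units; beyond the scatter).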

Compound 3, inhibition constant: 43 nM
For compound 3 the middle estimate is 1.2-fold (0.07 log units) above the measured one; measured number inside the range.
By their numbers in this assay, from the lowest: compounds 1 and 3 (each within the scatter of the next); then compound 2.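

In this assay, the gain from a benzyl group on the amine is not tied to iodine, since the 3-fluorobenzyl group also brings a 5.4-fold lower number from compound 2 to compound 3 (0.73 log units; beyond the scatter). Exchanging one halogen for the other leaves no clear difference, with a 1.7-fold higher number from compound 1 to compound 3 (0.22 log units; within the scatter) marking a gap that cannot be told from repeat-measurement noise. Nothing measured here explains why the benzyl groups bind better. From the compounds shown here alone, whether plain benzyl, with no halogen at all, keeps this gain stays open. So does the effect of a longer chain, as in phenethyl.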